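The compounds below may be only part of what the source reports. "The series", "measured", "known", "first", "only" and "open" are said of these compounds alone.

Compound 1 `C#CCOC(=O)CC1C(C(=O)OCC#C)=C(N)Oc2ccc(-c3cc(OC)cc(OC)c3)cc21` gives 1500 nM in a functional assay on HL-60 cells (Homo sapiens) for cytotoxicity, read by CellTiter-Blue, with a stated time of 48 h; a higher number here means a weaker inhibitor, a lower number a stronger inhibitor. In this assay compound 3 `C#CCOC(=O)CC1C(C(=O)OCC)=C(N)Oc2ccc(-c3cccc(NCC)c3)cc21` gives 17200 nM. Compound 2 `CCOC(=O)CC1C(C(=O)OCC)=C(N)Oc2ccc(-c3ccco3)cc21` reaches only a limit of the assay, > 80000 nM in this assay, as shown by the limit of > 80000 nM in this assay, at which 1 of the 3 values shown sits. Compound 4 `CCOC(=O)CC1C(C(=O)OCC)=C(N)Oc2ccc(-c3cccc(C(N)=O)c3)cc21` differs from compound 2 in one place: 3-carbamoylphenyl in place of furan-2-yl on an aromatic carbon. For the measured compounds named here, no pair among the measured compounds differs in a single place, so the size of such a step has not been seen here. With compound 2 sitting at a limit, the expectation for compound 4 is a step of an at least 1.3-fold lower number from compound 2 to compound 4 (0.12 log units; that floor lies within the scatter) that does not go beyond the usual scatter, and a result that may again be reported only as a limit. Compound 4 is therefore estimated at 60000 nM, within a range from 15000 nM to 200000 nM.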

Compound 4, half-maximal inhibitory concentration: 5400 nM
Estimate against measurement, compound 4: 11-fold (1.05 log units) above; the measured number lies below the stated range.
By their numbers in this assay, from the lowest: compound 1; then compound 4; then compound 3. At a limit, above all of these: compound 2.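

In this assay, for the compounds shown here, 3-carbamoylphenyl in place of furan-2-yl on this aromatic carbon gives an at least 14-fold lower number from compound 2 to compound 4 (1.17 log units; beyond the scatter), the first single-place step in this set, and it shows that the group on this carbon can move the number beyond the scatter. Compound 2 stands at a limit of the assay, so this step sets only a lower bound on the size of the change: the limit of > 80000 nM in this assay, at which 1 of the 4 values shown sits.

The compounds shown do not separate the effect of the carbamoyl group from that of the change of ring. A plain phenyl group, or a carboxylic acid in place of the carbamoyl, would be needed on this carbon to tell the two apart.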